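A few compounds are considered here, and "the series" means these few. Any claim that something is new, unique, unknown or untested is made for them only; others in the source may bear on it.

Measured in an in vitro ADME assay on microsomes from liver (Rattus norvegicus) for metabolic stability; a lower number here means slower removal, a higher number faster removal of the compound:
Compound 1 `C#CCN(CCOC)C(=O)[C@@]1(c2ccsc2)C[C@H]1CN`: 18 mL/min/kg
Compound 2 `C=C(F)CN(C)C(=O)[C@@]1(c2ccsc2)C[C@H]1CN`: 32 mL/min/kg

Compound 2 stands at 32 mL/min/kg and compound 1 at 18 mL/min/kg. These two numbers lie within the usual scatter of each other, so neither can be set apart from the other.

Compound 3 `C=C(F)CN(CCOC)C(=O)[C@@]1(c2ccsc2)C[C@H]1CN` has not yet been measured. It differs from compound 2 in one place: methoxymethyl in place of hydrogen on a saturated chain carbon bound to an amide-type nitrogen. In words, this is methoxymethyl in place of hydrogen on a saturated chain carbon bound to an amide-type nitrogen, which can also be read as methyl to 2-methoxyethyl.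

Going by the values given here, no pair of measured compounds shows this change on its own, so the data offer no direct guide to its size in this assay. Among the compounds with values here, the only hint is compound 1, which also carries a 2-methoxyethyl chain and gives 18 mL/min/kg. The expected shift is therefore small, slightly downward and not beyond the scatter, an estimated 1.2-fold lower number from compound 2 to compound 3 (0.09 log units; within the scatter). For compound 3 the expected clearance is 26 mL/min/kg, with an estimated range from 14 mL/min/kg to 48 mL/min/kg.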

Compound 3, clearance: 54 mL/min/kg
Estimate against measurement, compound 3: 2.1-fold (0.32 log units) below; the measured number lies above the stated range.
By their numbers in this assay, from the lowest: compounds 1, 2 and 3 (each within the scatter of the next, the first and the last beyond it).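

In this assay, methyl to 2-methoxyethyl gives a 1.7-fold higher number from compound 2 to compound 3 (0.23 log units; within the scatter) and stays within the scatter, so with the 1-fluoroethenyl group held in place, these two chains cannot be told apart. With the 2-methoxyethyl chain held in place instead, 1-fluoroethenyl in place of ethynyl on a saturated chain carbon bound to an amide-type nitrogen gives a 3.0-fold higher number from compound 1 to compound 3 (0.48 log units; beyond the scatter) and lies beyond the scatter, though the step is modest. This is the first single change among these compounds that can be separated from the scatter, and nothing measured here accounts for it.

It remains open whether the step from ethynyl to 1-fluoroethenyl would have a similar size with methyl as the other chain, as the compounds shown offer that comparison only with the 2-methoxyethyl chain. From the compounds shown here alone, it is also open how a saturated propyl group in place of 1-fluoroethenyl, or a 2-hydroxyethyl chain in place of 2-methoxyethyl, would read in this assay on the shared core.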